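The source may report more compounds than this note shows. Statements on the series, on what has been measured and on what is new or still open speak of the compounds shown alone.

Compound 1 `O=C1c2ccccc2CN1c1cnc(NCc2c(F)ccc3c2CCO3)n2cnnc12`: 13 mL.min-1.g-1
Compound 2 `COCCC(=O)Nc1cnc(NCc2c(F)ccc3c2CCO3)n2cnnc12`: < 3 mL.min-1.g-1 (a limit of the assay)
Compound 3 `CN(c1ccn(C)n1)c1cnc(NCc2c(F)ccc3c2CCO3)n2cnnc12`: 11 mL.min-1.g-1

In an ADME assay on microsomes from liver (Homo sapiens) for metabolic stability, read by LC-MS, using NADPH, with stated times of 5 min and 30 min, tested at 1 uM (on this read-out higher numbers stand for fast clearance and lower numbers for slow clearance), compound 3 gives 11 mL.min-1.g-1. It stands level with compound 1, since a 1.2-fold lower number from compound 1 to compound 3 (0.07 log units; within the scatter) lies within the scatter. Compound 4 `O=C1CCCN1c1cnc(NCc2c(F)ccc3c2CCO3)n2cnnc12` differs from compound 3 in one place: 2-oxopyrrolidin-1-yl in place of methyl(1-methyl-1H-pyrazol-3-yl)amino on an aromatic carbon. The entering 2-oxopyrrolidin-1-yl has a five-membered non-aromatic ring, as the group of compound 1 does, but it is smaller. Replacing that group of compound 1 with the ringless group of compound 2 gave an at least 4.3-fold lower number from compound 1 to compound 2 (0.63 log units; beyond the scatter), a step beyond the scatter. Compound 4 resembles both, so a small drop is expected, probably not beyond the scatter. The expected change is a 1.8-fold lower number from compound 3 to compound 4 (0.26 log units; within the scatter). Compound 4 is estimated at 6 mL.min-1.g-1, with an expected range of 3 mL.min-1.g-1 to 13 mL.min-1.g-1.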

Compound 4, intrinsic clearance in microsomes: < 3 mL.min-1.g-1
Compound 4: a limit, no number (the forecaster's own chance of this, stated with the estimate: 20%); middle value at least 2.0-fold (0.30 log units) away from the limit.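

In this assay, 2-oxopyrrolidin-1-yl on this aromatic carbon gives an at least 3.6-fold lower number from compound 3 to compound 4 (0.56 log units; beyond the scatter), and also an at least 4.3-fold lower number from compound 1 to compound 4 (0.63 log units; beyond the scatter). Compound 1 and compound 4 both carry a five-membered non-aromatic ring, so that ring alone does not go with the higher number, and a ringless group as in compound 2 is not needed for a low reading. Compound 2 and compound 4 each read as a limit of the assay, so the step between them cannot be read: the limit of < 3 mL.min-1.g-1 in this assay, at which 2 of the 4 values shown sit.

From the compounds shown here alone, whether a six-membered 2-oxopiperidin-1-yl or a plain amine at this position would also read low stays open.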